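Extending the chain of compound 2

The source may hold more compounds than are shown below. What is called first, only, known or untested is meant among the compounds shown, and "the series" means these compounds.

In a physicochemical assay for lipophilicity (on this read-out lower numbers stand for lower lipophilicity and higher numbers for higher lipophilicity), compound 1 (`CCCCCCCCCCCCNCCO`) gives 3.93 and compound 2 (`CCCCCCCCCCCCNCCCN`) gives 5.06 as the higher of the two numbers. Compound 3 (`CCCCCCCCCCCCCCNCCCN`) differs from compound 2 by ethyl in place of hydrogen on a saturated chain carbon, ten or more bonds along the chain from an amine nitrogen in one place, with ethyl in place of hydrogen on a saturated chain carbon, ten or more bonds along the chain from an amine nitrogen. Among the measured compounds shown here, the only measured guide is a number 1.13 log units higher from compound 1 to compound 2 (beyond the scatter) as a large step, though it comes from a different change. The step expected in this assay is upward and of similar size, estimated as a number 0.94 log units higher from compound 2 to compound 3 (beyond the scatter) for now. Compound 3 is estimated at 6 with 5.5 to 6.5 as its range.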

Compound 3, partition coefficient: 4.88
Beside the measured number, compound 3's estimate is 1.12 log units above it, and the stated range ends above it.
By their numbers in this assay, from the lowest: compound 1; then compounds 3 and 2 (each within the scatter of the next).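

In this assay, ethyl in place of hydrogen on a saturated chain carbon, ten or more bonds along the chain from an amine nitrogen, gives a number 0.18 log units lower from compound 2 to compound 3 (within the scatter), so this read-out does not separate the two compounds. The size of the earlier step, a number 1.13 log units higher from compound 1 to compound 2 (beyond the scatter), which came from a different change at a different place, did not carry over to this position. On these data alone, whether a longer chain or a carboxylic acid at this place would give a step beyond the scatter remains open. Nothing available bears on what lies behind this result.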